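Notes on the step from compound 3 to compound 4

This account rests on a few compounds, and the source may have more. Where it says the series, first, only, none or still open, it means among the compounds named here.

Measured so far in a functional assay on HepG2 cells (Homo sapiens) for antiproliferative activity, read by MTT assay, with a stated time of 48 h; a lower number here means a stronger inhibitor, a higher number a weaker inhibitor:
- compound 1 `CC1(C)CC(NC(=O)c2ccc(Nc3ncc([N+](=O)[O-])c(N4CCN(c5ccc(F)cc5)CC4)n3)cc2)CC(C)(C)N1[O]` gives 13100 nM
- compound 2 `Cc1cc(Nc2nc(Nc3ccc(C(=O)NC4CC(C)(C)N([O])C(C)(C)C4)cc3)ncc2[N+](=O)[O-])no1` gives 7360 nM
- compound 3 `Cc1cc(Nc2nc(Nc3ccc(C(=O)NC4CC(C)(C)N([O])C(C)(C)C4)cc3)ncc2F)no1` gives 10800 nM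

Compound 3 lies within the scatter of both compound 1 and compound 2, so the three numbers form a single group with no separation among them.

The change leading to compound 4 `CC(C)OC(=O)Cc1csc(Nc2nc(Nc3ccc(C(=O)NC4CC(C)(C)N([O])C(C)(C)C4)cc3)ncc2F)n1` reads 4-((isopropoxycarbonyl)methyl)-1,3-thiazol-2-yl in place of 5-methyl-1,2-oxazol-3-yl on a nitrogen on an aromatic ring and the shared core stays as it is. Among the compounds with values here, the entering group has no measured counterpart in this small set.

Within the data shown here, the one measured step is a 1.5-fold higher number from compound 2 to compound 3 (0.17 log units; within the scatter) and it concerns fluoro in place of nitro on an aromatic carbon. It therefore gives no direct reading of the present change. As far as these compounds go, with so little evidence, no shift beyond the scatter is expected in this assay and the direction stays open. The expected step is a 1.2-fold lower number from compound 3 to compound 4 (0.08 log units; within the scatter) and this is a weak expectation.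

For compound 4 the estimate is 9000 nM with a range from 3500 nM to 25000 nM expected.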

Compound 4, half-maximal inhibitory concentration: 13400 nM
Compound 4: middle estimate off by 1.5-fold (0.17 log units), on the low side, and the stated range covers the measured number.
By their numbers in this assay, from the lowest: compounds 2, 3, 1 and 4 (each within the scatter of the next).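

In this assay, 4-((isopropoxycarbonyl)methyl)-1,3-thiazol-2-yl in place of 5-methyl-1,2-oxazol-3-yl on this nitrogen gives a 1.2-fold higher number from compound 3 to compound 4 (0.09 log units; within the scatter). The earlier step concerned only fluoro and nitro on an aromatic carbon, whereas this step gives a direct reading at the nitrogen, where a larger group carrying an ester leaves compound 4 unseparated from compound 3. The data at hand offer no measurement that could account for this result.

Still open, as far as these compounds go, is whether the ring or its side chain governs the reading, and a carboxylic acid in place of the isopropyl ester, or a plain methyl on the same 1,3-thiazol-2-yl ring, would help to separate the two. Also open, from the compounds shown here alone, is whether any group on this nitrogen can move the number beyond the scatter in this assay.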